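Replacing Fluoro with Methyl in Compound 3

A few compounds are considered here, and "the series" means these few. Any claim that something is new, unique, unknown or untested is made for them only; others in the source may bear on it.

In a functional assay on CCRF-CEM cells (Homo sapiens) for inhibition (a lower number here means a stronger inhibitor, a higher number a weaker inhibitor), compound 1 (`O=C1/C(=C/c2ccc(Cl)cc2)Cc2ccccc21`) gives 284000 nM and compound 2 (`O=C1/C(=C/c2ccc(Br)cc2)Cc2ccccc21`) gives 284000 nM. Compound 3 (`O=C1CCCCC/C1=C\c1cccc(F)c1`), built on a different core, gives 224000 nM, which lies within the scatter of both of the other values. The next compound to be measured is compound 4 (`Cc1cccc(/C=C2\CCCCCC2=O)c1`), which carries methyl in place of fluoro on an aromatic carbon. Among the compounds with values here, only one measured step offers any guidance, and it is indirect. It is a swap of one halogen for another on the core of compound 1, no change at the digits printed from compound 1 to compound 2 (within the scatter). Within the data shown here, no measured pair shows methyl in place of fluoro, so this evidence is thin. With that single step inside the scatter, and all three values close together, no shift beyond the scatter is expected. The expected step is a 1.0-fold higher number from compound 3 to compound 4 (0.01 log units; within the scatter). For compound 4 the estimated value is 230000 nM, with an expected range of 120000 nM to 420000 nM.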

Compound 4, half-maximal inhibitory concentration: 170000 nM
Compound 4: middle estimate off by 1.4-fold (0.13 log units), on the high side; the range from low to high includes it.
By their numbers in this assay, from the lowest: compounds 4, 3, 1 and 2 (each within the scatter of the next).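

In this assay, the change from fluoro to methyl on an aromatic carbon, meta to a group of 9 heavy atoms, gives a 1.3-fold lower number from compound 3 to compound 4 (0.12 log units; within the scatter). Within the data shown here, this is the first direct reading at this position, and it extends what the earlier compounds showed: their one step was a swap of one halogen for another on the core of compound 1, whereas here a halogen gives way to a carbon group with the number still inside the scatter. Since fluoro and methyl each count one heavy atom, with no hydrogen-bond donors or acceptors and no net charge, the step tests only a small exchange.

Going by these compounds, whether an amine, a carboxylic acid or a longer chain at this position would move the number beyond the scatter remains open. No independent measurement bears on this step.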